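Vinyl for Fluoro on the Thiophene Series

The source may hold more compounds than are shown below. What is called first, only, known or untested is meant among the compounds shown, and "the series" means these compounds.

Measured compounds:
compound 1, `C=C1CCC(c2csc(/C=C(\C)C(N)=O)c2)CC1`, 5010 nM;
compound 2, `C/C(=C\c1cc(-c2ccc(F)cc2)cs1)C(N)=O`, 20800 nM;
compound 3, `C/C(=C\c1nc(-c2ccc(F)cc2)cs1)C(N)=O`, 5400 nM.

In a functional assay on HeLa cells (Homo sapiens) for cytotoxicity, read by CCK-8 assay, with a stated time of 24 h (a lower number here means a stronger inhibitor, a higher number a weaker inhibitor), compound 2 gives the highest of the three numbers. Its nearest neighbour is compound 3, whose value of 5400 nM is lower by a gap beyond the scatter, and compound 1 with 5010 nM lies slightly further still. Compound 4, `C=Cc1ccc(-c2csc(/C=C(\C)C(N)=O)c2)cc1`, differs from compound 2 by one change: vinyl in place of fluoro on an aromatic carbon. Going by the values given here, no step between measured compounds isolates this change. The expected step from compound 2 to compound 4 is therefore a modest move toward a lower number, a 1.7-fold lower number from compound 2 to compound 4 (0.24 log units; within the scatter), of a size near the edge of the scatter. The estimate for compound 4 in this assay is 12000 nM, with a range of 4000 nM to 36000 nM.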

Compound 4, half-maximal inhibitory concentration: > 50000 nM
Compound 4: no number, only a limit (the forecaster's own chance of this, stated with the estimate: 10%); at least 4.1-fold (0.61 log units) between middle value and limit.
By their numbers in this assay, from the lowest: compounds 1 and 3 (each within the scatter of the next); then compound 2. At a limit, above all of these: compound 4.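

In this assay, going by these compounds alone, the position para to a large group on the six-membered aromatic ring responds to a change of substituent, something no earlier pair of compounds could show. Vinyl in place of fluoro gives an at least 2.4-fold higher number from compound 2 to compound 4 (0.38 log units; beyond the scatter), a move beyond the scatter and toward weaker inhibition. Compound 4 stands at a limit of the assay rather than at a number: the limit of > 50000 nM in this assay, at which 1 of the 4 values shown sits.

From the compounds shown here alone, how far the true value of compound 4 lies past that limit remains open. So does whether an amine, a carboxylic acid or a longer chain at this position would keep or lose the activity of compound 2.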